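Double-bond configuration in the series: compound 3 to compound 4

The source may report more compounds than this note shows. Statements on the series, on what has been measured and on what is new or still open speak of the compounds shown alone.

Measured in a functional assay on HL-60 cells (Homo sapiens) for cytotoxicity; a lower number here means a stronger inhibitor, a higher number a weaker inhibitor:
- compound 1 `COc1c(O)cc2c3c1C[C@@H](C)C[C@H](OC)[C@H](O3)[C@@H](C)/C=C(\C)[C@H](OC(N)=O)[C@@H](OC)C[C@@H](O)/C=C(\C)C(=O)N2`: "not active" (no number reported)
- compound 2 `COc1c(O)cc2c3c1C[C@@H](C)C[C@H](OC)[C@H](O3)[C@@H](C)/C=C(\C)[C@H](OC(N)=O)[C@@H](OC)/C=C\C=C(/C)C(=O)N2`: 27000 nM
- compound 3 `COc1c(O)cc2c3c1C[C@@H](C)C[C@H](OC)[C@H](O3)[C@@H](C)/C=C(\C)[C@H](OC(N)=O)[C@@H](OC)/C=C/C=C(\C)C(=O)N2`: 35000 nM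

Among the compounds with values here, only two numbers exist in this assay, and they lie within the scatter of each other, so compound 3 sits level with compound 2. Compound 1 has no number to compare.

The next case is compound 4 `COc1c(O)cc2c3c1C[C@@H](C)C[C@H](OC)[C@H](O3)[C@@H](C)/C=C(\C)[C@H](OC(N)=O)[C@@H](OC)/C=C\C=C(\C)C(=O)N2`, set against compound 3: the two compounds have the same atoms and bonds and differ only in configuration as drawn: 2 of 9 stereo elements differ; a double bond is drawn E in compound 3 and Z in compound 4; a double bond is drawn E in compound 3 and Z in compound 4. Nothing leaves and nothing enters, so the whole question is one of configuration.

Within the data shown here, one measured step bears on this: a 1.3-fold higher number from compound 2 to compound 3 (0.11 log units; within the scatter). It comes with the fact that compounds 2 and 3 differ only in the configuration as drawn, so it is the same kind of change, though it touches fewer stereo elements than the change to compound 4. On that single step, no shift beyond the scatter is expected, and no direction can be assigned. The evidence is thin, so the range is kept wide, and a report without a number remains possible.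

The expected step is a 1.2-fold lower number from compound 3 to compound 4 (0.07 log units; within the scatter). For compound 4 the estimated value is 30000 nM, with an expected range from 10000 nM to 80000 nM.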

Compound 4, half-maximal inhibitory concentration: 48000 nM
Compound 4: middle estimate off by 1.6-fold (0.20 log units), on the low side, within the range that was stated.
By their numbers in this assay, from the lowest: compounds 2, 3 and 4 (each within the scatter of the next).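

In this assay, the change at two double bonds together stays within the scatter: a 1.4-fold higher number from compound 3 to compound 4 (0.14 log units; within the scatter). The earlier compounds shown here had tested only one double bond, and the second single change, at the other double bond, also stays within the scatter: a 1.8-fold higher number from compound 2 to compound 4 (0.25 log units; within the scatter). No atoms enter or leave in either comparison, so these readings concern configuration alone, and across the three compounds with numbers neither double bond, alone or together with the other, gives a difference beyond the scatter: the fact that compounds 3 and 4 differ only in the configuration as drawn.

With all three numbers so close, no preferred double-bond configuration can be named, and the compounds shown give no reason for the weak cytotoxicity they share. From the compounds shown here alone, it remains open whether an amine or a carboxylic acid on the shared core, or a longer chain in place of one of the methoxy groups, would give a number outside this narrow band, and whether any such change would make double-bond configuration matter.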